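Amide variation on a shared core: cytotoxicity notes

The compounds below may be only part of what the source reports. "The series", "measured", "known", "first", "only" and "open" are said of these compounds alone.

Measured so far:
compound 1 `COc1ccc(-c2cnc(NC(=O)CCc3ccccc3)n2C)cc1` — > 100000 nM
compound 2 `COc1ccc(-c2cnc(NC(=O)c3cccc(C#N)c3)n2C)cc1` — > 100000 nM
compound 3 `CCC(=O)Nc1ncc(-c2ccc(OC)cc2)n1C` — > 100000 nM

In a toxicity assay on THP-1 cells (Homo sapiens) for inhibition (a higher number here means that more compound is tolerated, a lower number that less compound is tolerated), compound 1 gives > 100000 nM, which is a limit of the assay and not a number. In this assay compound 2 gives > 100000 nM, again a limit. In this assay compound 3 gives > 100000 nM, also a limit. Among the measured compounds shown here, compound 3 therefore stands at the limit of > 100000 nM in this assay, at which 3 of the 3 values shown sit, together with the other two, and none of the measured steps can be read: a step that the two limits leave unreadable from compound 1 to compound 2, a step that the two limits leave unreadable from compound 1 to compound 3 and a step that the two limits leave unreadable from compound 2 to compound 3 all stay hidden by the two limits.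

The next compound, compound 4 `COc1ccc(-c2cnc(NC(=O)c3ccccc3Cl)n2C)cc1`, differs from compound 3 by 2-chlorophenyl in place of ethyl on a carbonyl carbon. The step from compound 3 to compound 2, in which an aromatic ring also replaces ethyl on the carbonyl carbon, bears on it most directly, but its size is unreadable. Every amide tried on the shared core has sat at the limit, so no change beyond the scatter is expected from this replacement. The step that the limit leaves unreadable from compound 3 to compound 4 is thus expected to be flat. Compound 4 is estimated at 150000 nM, with a range from 50000 nM to 500000 nM, most likely reported as a limit again.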

Compound 4, half-maximal cytotoxic concentration: > 50000 nM
Compound 4: only a limit was reported (the forecaster's own chance of this, stated with the estimate: 80%); the middle value is on the limit's open side.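

Compound 4 gives > 50000 nM in this assay, which is a limit and not a number, so the steps to compound 4 from compound 1, compound 2 and compound 3 cannot be read. The compounds shown leave open at what concentration any of these four amides would reach a half-maximal cytotoxic effect.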